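The source may report more compounds than this note shows. Statements on the series, on what has been measured and on what is new or still open speak of the compounds shown alone.

Measured so far, in a functional assay on NCI/ADR cells (Homo sapiens) for cytotoxicity, read by sulforhodamine B assay; a higher number here means a weaker inhibitor of growth, a lower number a stronger inhibitor of growth: compound 1 `CC1=CC[C@@H]([C@@](C)(O)CCCC(C)(C)NC(=S)NN)CC1` gives 760 nM; compound 2 `CC1=CC[C@@H]([C@@](C)(O)CCCC(C)(C)NC(=S)N/N=C\c2ccccc2)CC1` gives 6970 nM; compound 3 `CC1=CC[C@@H]([C@@](C)(O)CCCC(C)(C)NC(=S)N/N=C\c2ccc(Cl)cc2)CC1` gives 7580 nM.

Compound 3 sits at the highest number of the three, though its gap to compound 2 is within the scatter, while a 10-fold higher number from compound 1 to compound 3 (1.00 log units; beyond the scatter). Compound 4 `CC1=CC[C@@H]([C@@](C)(O)CCCC(C)(C)NC(=S)N/N=C(/C)c2ccccc2)CC1` differs from compound 3 by a group of 9 heavy atoms (8 carbon, 1 nitrogen; one six-membered aromatic ring of carbon only) in place of a group of 9 heavy atoms (7 carbon, 1 nitrogen, 1 chlorine; one six-membered aromatic ring of carbon only), on an amide-type nitrogen. Going by the values given here, two measured steps bear on this: a 1.1-fold higher number from compound 2 to compound 3 (0.04 log units; within the scatter), so dropping the chloro is expected to matter little, and a 9.2-fold higher number from compound 1 to compound 2 (0.96 log units; beyond the scatter) together with a 10-fold higher number from compound 1 to compound 3 (1.00 log units; beyond the scatter) show that this kind of substituent on the hydrazine nitrogen costs roughly the same regardless of the aromatic ring's substitution. Among the compounds with values here, no measured step covers the added methyl on the double bond. Compound 4 is therefore expected to stay near compound 3, giving a 1.1-fold lower number from compound 3 to compound 4 (0.03 log units; within the scatter). The estimate for compound 4 in this assay is 7000 nM, with a range from 2800 nM to 17500 nM.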

Compound 4, concentration for 50% growth inhibition: 750 nM
For compound 4 the middle estimate is 9.3-fold (0.97 log units) above the measured one; measured number below the stated range.
By their numbers in this assay, from the lowest: compounds 4 and 1 (each within the scatter of the next); then compounds 2 and 3 (each within the scatter of the next).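

In this assay, the group entering on the amide-type nitrogen in compound 4 holds one more carbon than the group in compound 2, and this single change gives a 9.3-fold lower number from compound 2 to compound 4 (0.97 log units; beyond the scatter). The exchange for the chlorine-bearing group gives a 10-fold lower number from compound 3 to compound 4 (1.00 log units; beyond the scatter), while a 1.0-fold lower number from compound 1 to compound 4 (0.01 log units; within the scatter) places compound 4 level with compound 1, so a group with an aromatic ring at this nitrogen does not always bring the higher numbers of compound 2 and compound 3. No evidence here explains this shift. As far as these compounds go, whether a chloro on the aromatic ring of compound 4 would preserve its number remains open, as does the outcome with an ethyl group in place of the added methyl.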